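A few compounds are considered here, and "the series" means these few. Any claim that something is new, unique, unknown or untested is made for them only; others in the source may bear on it.

Among the measured compounds shown here, in a functional assay on P388 cells (Mus musculus) for antiproliferative activity (on this read-out higher numbers stand for weaker inhibition and lower numbers for stronger inhibition), compound 2 (`COc1ccc(S(=O)(=O)Nc2cccc3c(C#N)c[nH]c23)cc1`) gives 0.17 ug/mL, the lowest of the three numbers measured so far. Compound 3 (`N#Cc1ccc(S(=O)(=O)Nc2cccc3c(C#N)c[nH]c23)cc1`) gives 0.53 ug/mL and compound 1 (`COc1ccc(S(=O)(=O)Nc2cccc3cc[nH]c23)cc1`) gives 1.1 ug/mL, both higher by more than the scatter.

Compound 4 (`COc1ccc(S(=O)(=O)Nc2cccc3c(Cl)c[nH]c23)cc1`) has not yet been measured. It carries chloro in place of cyano on an aromatic carbon of a five-membered aromatic ring, two ring bonds from the ring nitrogen: chloro in place of cyano on an aromatic carbon.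

For the measured compounds named here, two measured steps bear on this change. The closer one put cyano in place of hydrogen at that same carbon and gave a 6.5-fold lower number from compound 1 to compound 2 (0.81 log units; beyond the scatter), a modest step beyond the scatter. The other put cyano in place of methoxy at a different aromatic carbon and gave a 3.1-fold higher number from compound 2 to compound 3 (0.49 log units; beyond the scatter), also modest, which shows that replacing a group on this series can raise the number by a moderate amount. Going by the values given here, no measured compound carries chloro, so the data do not show directly how chloro compares with cyano.

A small rise is expected in this assay, smaller than the gap to compound 1 and possibly not beyond the scatter. The estimated step is a 1.5-fold higher number from compound 2 to compound 4 (0.17 log units; within the scatter). For compound 4 the expected value is 0.25 ug/mL, with an estimated range of 0.08 ug/mL to 0.8 ug/mL.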

Compound 4, half-maximal inhibitory concentration: 0.76 ug/mL
Compound 4: middle estimate off by 3.0-fold (0.48 log units), on the low side; low and high end bracket the measured number.
By their numbers in this assay, from the lowest: compound 2; then compounds 3, 4 and 1 (each within the scatter of the next, the first and the last beyond it).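

In this assay, chloro in place of cyano gives a 4.5-fold higher number from compound 2 to compound 4 (0.65 log units; beyond the scatter) and shows that this carbon of the five-membered aromatic ring does not accept these two groups alike. Chloro in place of hydrogen at the same carbon gives a 1.4-fold lower number from compound 1 to compound 4 (0.16 log units; within the scatter) and leaves the two compounds indistinguishable in this assay. The earlier step of a 6.5-fold lower number from compound 1 to compound 2 (0.81 log units; beyond the scatter) is therefore not a shift seen with both groups placed here: among the three groups shown at this carbon, only cyano stands apart, and no evidence at hand accounts for the difference between cyano and chloro.

With only hydrogen, cyano and chloro shown at this carbon, it remains open whether the low number of compound 2 is particular to cyano or would also appear with another group here, such as an amine, a carboxylic acid, an ester or a longer chain. From the compounds shown here alone, it also remains open whether chloro would compare with cyano in the same way if cyano replaced the methoxy group at the other aromatic carbon, as it does in compound 3.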